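Swapping One Ring Group on an Amide Carbonyl

The source may hold more compounds than are shown below. What is called first, only, known or untested is meant among the compounds shown, and "the series" means these compounds.

Compound 1 `Cc1ccccc1S(=O)(=O)c1ccc(CNC(=O)c2cc3cnccc3[nH]2)cc1`: 15%
Compound 2 `O=C(NCc1ccc(S(=O)(=O)c2ccccc2)cc1)c1cc2ccncc2s1`: 21%
Compound 3 `O=C(NCc1ccc(S(=O)(=O)c2ccccc2)cc1)c1cc(-c2cccnc2)no1`: 66%

These three compounds were tested in an ADME assay on microsomes from liver (Mus musculus) for metabolic stability, read by LC-MS, with a stated time of 30 min, tested at 1 uM; on this read-out higher numbers stand for a more stable compound and lower numbers for a less stable compound. In this assay compound 2 gives 21%. That number lies within the usual scatter of compound 1 at 15%, so the two cannot be told apart. Compound 3 gives 66%, well beyond the scatter above compound 2.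

The next molecule is compound 4 `O=C(NCc1ccc(S(=O)(=O)c2ccccc2)cc1)c1c[nH]c2ccncc12`, which has not yet been measured. It differs from compound 2 in one place: a group of 9 heavy atoms (7 carbon, 2 nitrogen; one five-membered aromatic ring with 1 hetero atom, one six-membered aromatic ring with 1 hetero atom) in place of a group of 9 heavy atoms (7 carbon, 1 nitrogen, 1 sulfur; one five-membered aromatic ring with 1 hetero atom, one six-membered aromatic ring with 1 hetero atom), on a carbonyl carbon. Both groups have the same size and the same pair of aromatic rings, but they differ in their atoms.

For the measured compounds named here, no two measured compounds differ in only one place, so the data contain no direct measure of such a step. The nearest guide is compound 1 at 15%, which differs from compound 2 in more than one place yet stays within the scatter of it. Compound 3 at 66% shows that a much higher number is possible among these molecules, but it offers a weaker guide to this particular swap. No change beyond the scatter is expected, and the estimated move is a number 1 percentage points lower from compound 2 to compound 4 (within the scatter). For compound 4 the estimate is 20%, with an expected range from 8% to 40%.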

Compound 4, percent of the compound remaining: 45%
Estimate against measurement, compound 4: 25 percentage points below; measured number outside the range, above it.
By their numbers in this assay, from the lowest: compounds 1 and 2 (each within the scatter of the next); then compound 4; then compound 3.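

In this assay, the exchange on a carbonyl carbon whose other neighbour is an amide-type nitrogen gives a number 24 percentage points higher from compound 2 to compound 4 (beyond the scatter), the first direct reading of a change in one place among these molecules. The group that leaves and the group that enters have the same number of heavy atoms and the same pair of rings, one five-membered aromatic ring with 1 hetero atom and one six-membered aromatic ring with 1 hetero atom, so this position responds to a change in atoms even when group size and ring sizes stay the same. In this swap sulfur gives way to a second nitrogen, and the count moves from 0 hydrogen-bond donors, 2 hydrogen-bond acceptors to 1 hydrogen-bond donor, 1 hydrogen-bond acceptor, but no measurement here explains the rise.

This single step cannot separate the loss of sulfur from the gain of nitrogen or the gain of a hydrogen-bond donor, and it cannot show whether the same swap would act alike on another core. Going by these compounds, how a quite different group, such as a morpholine or a simple phenyl ring, would fare on the same carbonyl carbon also stays open.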